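The source may hold more compounds than are shown below. What is called first, only, known or untested is meant among the compounds shown, and "the series" means these compounds.

Of the compounds shown here, three have so far been tested in a functional assay on the whole organism with Mus musculus as the target, in the maximal electroshock model, at a dose of 50 mg/kg by the oral route; on this read-out higher numbers stand for more inhibition at the one dose given (going by the name of the read-out) and lower numbers for less inhibition. Compound 1 `CN(C)CCCCOc1ccccc1/C=C/c1ccccc1Cl` gives 14.3%, compound 2 `CCN1CCN(CCCCOc2ccccc2/C=C/c2ccccc2)CC1` gives 33.3%, and compound 3 `CCCN1CCN(CCCCOc2ccccc2/C=C/c2ccccc2)CC1` gives 42.9%. Compound 3 thus carries the highest of the three numbers: its separation from compound 1 lies beyond the scatter, whereas the step of a number 9.6 percentage points higher from compound 2 to compound 3 (within the scatter) lies within it, so compound 3 and compound 2 cannot be told apart on this read-out. Compound 4 `O=C(O)C1CCCN(CCCCOc2ccccc2/C=C/c2ccccc2)C1` has not yet been measured. It differs from compound 3 by 3-carboxypiperidin-1-yl in place of 4-propylpiperazin-1-yl on a saturated chain carbon, four bonds along the chain from an oxygen on an aromatic ring. For the measured compounds named here, the only measured step, a number 9.6 percentage points higher from compound 2 to compound 3 (within the scatter), concerns a small extension on a chain and does not bear on this exchange; no measured pair shows an acid entering in place of an amine, so the data give no direct guide. Compound 4 is therefore expected, with wide uncertainty, to give 25%, with a likely range from 5% to 50%. This would correspond to an estimated step of a number 17.9 percentage points lower from compound 3 to compound 4 (beyond the scatter), a drop that may or may not exceed the scatter.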

Compound 4, a percentage reported as inhibition, in the whole organism at one dose (the size of the read-out at that dose, not a potency): 12.5%
Compound 4: middle estimate off by 12.5 percentage points, on the high side; the range from low to high includes it.
By their numbers in this assay, from the lowest: compounds 4 and 1 (each within the scatter of the next); then compounds 2 and 3 (each within the scatter of the next).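

In this assay, for the compounds shown here, the exchange on a saturated chain carbon, four bonds along the chain from an oxygen on an aromatic ring, is the first single change that moves the number beyond the scatter. Placing 3-carboxypiperidin-1-yl there gives a number 30.4 percentage points lower from compound 3 to compound 4 (beyond the scatter) in place of 4-propylpiperazin-1-yl and a number 20.8 percentage points lower from compound 2 to compound 4 (beyond the scatter) in place of 4-ethylpiperazin-1-yl. The two piperazine compounds, which cannot be told apart from each other, therefore both separate from compound 4, showing that the group at this position can change the read-out where the small chain extension did not.

On these data alone, whether the drop goes with the carboxylic acid or with the piperidine ring stays open, and a plain piperidine or the methyl ester of the same acid at this position would separate the two. No measurement shown here accounts for the drop.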